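This account rests on a few compounds, and the source may have more. Where it says the series, first, only, none or still open, it means among the compounds named here.

In an in vitro ADME assay on microsomes from liver (Homo sapiens) for metabolic stability, read by LC-MS (a higher number here means that the compound lasts longer, a lower number that the compound disappears faster), compound 1 `CCON/C(=N\C1=NC(=O)C(=O)N1C(C)C)Nc1ccc(Cl)c(Cl)c1` gives > 1 h as a limit. Compound 2 `CC(C)N1C(=O)C(=O)N=C1/N=C(/Nc1ccc(Cl)c(Cl)c1)NC(C)(C)C` gives > 1 h as a limit too. Compound 3 `CC(C)N1C(=O)C(=O)N=C1/N=C(\NCc1ccccc1)Nc1ccc(Cl)c(Cl)c1` gives > 1 h and this is also a limit. The change to compound 4 `CC(C)N1C(=O)C(=O)N=C1/N=C(\NCCCN(C)C)Nc1ccc(Cl)c(Cl)c1` is 2-(dimethylamino)ethyl in place of phenyl on a saturated chain carbon bound to an amine nitrogen with 2-(dimethylamino)ethyl in place of phenyl on a saturated chain carbon bound to an amine nitrogen. For the measured compounds named here, three measured steps bear on it: a step that the two limits leave unreadable from compound 1 to compound 2 and a step that the two limits leave unreadable from compound 1 to compound 3 and a step that the two limits leave unreadable from compound 2 to compound 3 on the same amine nitrogen. None has a readable size because the limit of > 1 h in this assay, at which 3 of the 3 values shown sit, holds for all of them. No direction can be drawn from them, and no step beyond the scatter is expected. The expected step is a step that the limit leaves unreadable from compound 3 to compound 4 as an estimate only. The estimate for compound 4 is 1.3 h with an expected range from 0.6 h to 2.5 h in this read-out.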

Compound 4, half-life: > 1 h
Compound 4 was reported as a limit (the forecaster's own chance of this, stated with the estimate: 70%); the middle value lies beyond the limit too.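

In this assay compound 4 gives > 1 h, and this is a limit. The steps from compound 1, compound 2 and compound 3 to compound 4 cannot be read: the limit of > 1 h in this assay, at which 4 of the 4 values shown sit.

As far as these compounds go, whether the group on the amine nitrogen changes the half-life at all in these four compounds stays open.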